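Changing Configuration at Two Ring Stereocentres of Compound 2

This account rests on a few compounds, and the source may have more. Where it says the series, first, only, none or still open, it means among the compounds named here.

In an ADME assay on liver for metabolic stability, with Liver microsome (Homo sapiens) as the target, read by LC-MS, using microsomes, with a stated time of 5 h (a higher number here means faster removal of the compound, a lower number slower removal), compound 1 `O[C@H](c1ccccn1)[C@]1(c2ccc(C(F)(F)F)cc2)C[C@@H](O)C1` gives 33.3 mL/min/kg, compound 2 `C[C@]1(O)C[C@@](c2ccc(C(F)(F)F)cc2)([C@H](O)c2ccccn2)C1` gives 50 mL/min/kg and compound 3 `C[C@]1(O)C[C@@](c2ccc(OC(F)(F)F)cc2)([C@H](O)c2ccccn2)C1` gives 66.7 mL/min/kg. Compound 2 lies within the scatter of both others. Methyl in place of hydrogen on a saturated ring carbon gives a 1.5-fold higher number from compound 1 to compound 2 (0.18 log units; within the scatter), and trifluoromethoxy in place of trifluoromethyl on an aromatic carbon gives a 1.3-fold higher number from compound 2 to compound 3 (0.13 log units; within the scatter).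

Compound 4 `C[C@]1(O)C[C@](c2ccc(C(F)(F)F)cc2)([C@H](O)c2ccccn2)C1` keeps the atoms and bonds of compound 2: the two compounds have the same atoms and bonds and differ only in configuration as drawn: 2 of 3 stereo elements differ; a stereocentre at a saturated ring carbon is drawn R in compound 2 and S in compound 4; a stereocentre at a saturated ring carbon is drawn s in compound 2 and r in compound 4. Neither measured step changes configuration alone, so both offer only an indirect guide, and no shift beyond the scatter is expected in this assay. The expected step is no change at the digits printed from compound 2 to compound 4 (within the scatter). The estimate for compound 4 is 50 mL/min/kg, with an expected range of 25 mL/min/kg to 95 mL/min/kg.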

Compound 4, clearance: 33.3 mL/min/kg
Compound 4: middle estimate off by 1.5-fold (0.18 log units), on the high side, and the stated range covers the measured number.
By their numbers in this assay, from the lowest: compounds 1, 4, 2 and 3 (each within the scatter of the next).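

In this assay the swap of two ring stereocentres gives a 1.5-fold lower number from compound 2 to compound 4 (0.18 log units; within the scatter) and so stays inside the usual scatter. The earlier steps each exchanged one group for another, whereas this one tests arrangement in space by itself, and the comparison is clean for one reason: the fact that compounds 2 and 4 differ only in the configuration as drawn.

Still open, from the compounds shown here alone, is whether configuration matters as little with an amine or a carboxylic acid on the saturated ring. Also open, going by these compounds, is what changing only one of these two stereocentres would do.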